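This account rests on a few compounds, and the source may have more. Where it says the series, first, only, none or still open, it means among the compounds named here.

Measured so far:
compound 1, `N#Cc1cc2c(Oc3ccc(F)cc3OCCn3ccc(=O)[nH]c3=O)cccn2c1`: 100000 nM
compound 2, `N#Cc1cc2c(Oc3ccc(F)cc3OCCn3ccc(=O)[nH]c3=O)cc(F)cn2c1`: 50000 nM

In an ADME assay on MT2 cells (Homo sapiens) for cytotoxicity, read by MTT assay (on this read-out higher numbers stand for lower toxicity in this test and lower numbers for higher toxicity in this test), compound 2 gives 50000 nM, the lowest of the two numbers here, and its nearest neighbour is compound 1 with 100000 nM. Within the data shown here, the one measured step, a 2.0-fold lower number from compound 1 to compound 2 (0.30 log units; within the scatter), lies within the scatter, so the two numbers cannot be told apart.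

Compound 3 is `N#Cc1cc2c(Oc3ccc(F)cc3OCCn3ccc(=O)[nH]c3=O)cc(Cl)cn2c1`. It differs from compound 2 by chloro in place of fluoro on an aromatic carbon. Among the measured compounds shown here, no measured step swaps chloro for fluoro at this place; the only step at hand swaps fluoro for hydrogen there, and that step stayed within the scatter. On that basis a step from compound 2 to compound 3 of no more than the scatter is expected, with a slight lean toward a lower number.

For compound 3 the expected value in this assay is therefore 40000 nM, between 15000 nM and 100000 nM, which means an expected step of a 1.3-fold lower number from compound 2 to compound 3 (0.10 log units; within the scatter).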

Compound 3, half-maximal cytotoxic concentration: 15000 nM
For compound 3 the middle estimate is 2.7-fold (0.43 log units) above the measured one, within the range that was stated.
By their numbers in this assay, from the lowest: compound 3; then compounds 2 and 1 (each within the scatter of the next).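

In this assay, this position now shows a change larger than the scatter: chloro in place of fluoro on the aromatic carbon gives a 3.3-fold lower number from compound 2 to compound 3 (0.52 log units; beyond the scatter) and so moves toward higher toxicity in this test, whereas the earlier swap of fluoro for hydrogen could not be told apart from scatter. Chloro in place of hydrogen gives a 6.7-fold lower number from compound 1 to compound 3 (0.82 log units; beyond the scatter) on the same core, so at this place the two halogens do not behave alike in this test. Nothing available here explains the difference between chloro and fluoro at this position.

The compounds shown leave open how bromo, methyl, methoxy or an amine at this aromatic carbon would read in this test. They also leave open whether chloro would give a similar step elsewhere on the shared core.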